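This account rests on a few compounds, and the source may have more. Where it says the series, first, only, none or still open, it means among the compounds named here.

Compounds measured in a functional assay on the whole organism with Rattus norvegicus as the target, at a dose of 40 mg/kg by the intraperitoneal route; on this read-out lower numbers stand for less inhibition and higher numbers for more inhibition at the one dose given (going by the name of the read-out):
compound 1, `Cc1nc2c(OCc3ccccc3)cccn2c1N`: 99%
compound 2, `CC(=O)Nc1c(C)nc2c(OCc3ccccc3)cccn12`: 93%
compound 3, `COC(=O)Nc1c(C)nc2c(OCc3ccccc3)cccn12`: 0%

Compound 3 stands lowest of the three; its nearest neighbour is compound 2, and the gap between them is beyond the scatter, as is the gap to compound 1. Compound 4, `CNc1c(C)nc2c(OCc3ccccc3)cccn12`, differs from compound 3 by methyl in place of methoxycarbonyl on a nitrogen on an aromatic ring. Going by the values given here, two measured steps bear on this change. The first is a number 99 percentage points lower from compound 1 to compound 3 (beyond the scatter), the second is a number 93 percentage points lower from compound 2 to compound 3 (beyond the scatter). Both show that the methoxycarbonyl on the nitrogen on the aromatic ring goes with a much lower number, while hydrogen and acetyl at that nitrogen, in compound 1 and compound 2, go with a far higher number in this assay. Removing the methoxycarbonyl in favour of methyl is therefore expected to reverse most of that drop in the number: the step is estimated as a number 85 percentage points higher from compound 3 to compound 4 (beyond the scatter), and compound 4 is expected to give about 85%, in a range from 40% to 100%.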

Compound 4, a percentage reported as inhibition, in the whole organism at one dose (the size of the read-out at that dose, not a potency): 55%
The estimate for compound 4 lay 30 percentage points above the measured number, within the range that was stated.
By their numbers in this assay, from the lowest: compound 3; then compound 4; then compounds 2 and 1 (each within the scatter of the next).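

In this assay, the step is a number 55 percentage points higher from compound 3 to compound 4 (beyond the scatter), so a substituent on this nitrogen other than hydrogen or acetyl can still give a sizeable number, and the near-absence of inhibition stays specific to the methoxycarbonyl among the groups shown. Methyl does not reach the level of the other two, however: the steps are a number 38 percentage points lower from compound 2 to compound 4 (beyond the scatter) and a number 44 percentage points lower from compound 1 to compound 4 (beyond the scatter). The groups on this nitrogen therefore fall into three levels rather than two, and that order does not follow heavy-atom count, with hydrogen and acetyl together at the top. No measurement here gives a reason for these differences.

The compounds shown leave open where an ethyl group or a second methyl on this nitrogen would fall. They also leave open whether a longer acyl chain such as propionyl would stay with acetyl.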